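The compounds below may be only part of what the source reports. "The series", "measured", "known", "first", "only" and "open" are said of these compounds alone.

Three compounds that share one core have been run through an ADME assay on S9 fraction from liver (Mus musculus) for metabolic stability, read by LC-MS, using NADPH, with a stated time of 45 min, tested at 3 uM, in the presence of a further agent that is not named here; on this read-out higher numbers stand for higher hepatic extraction and lower numbers for lower hepatic extraction. Compound 1 `COc1ccc(-n2cnc3cnc(Nc4cccc(NS(C)(=O)=O)c4)cc32)cc1OC` gives 0.58 in this assay, and compound 2 `COc1ccc(-n2cnc3cnc(Oc4cccc(NC(C)=O)c4)cc32)cc1OC` gives 0.19. Compound 3 `COc1ccc(-n2cnc3cnc(-c4ccccc4C)cc32)cc1OC` stands highest of the three: in this assay compound 3 gives 1, which lies beyond the scatter above compound 1 and further still beyond the scatter above compound 2. Within the data shown here, none of these three differs from another in only one place, so no single step among the measured compounds can be read off.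

Compound 4 `COc1ccc(-n2cnc3cnc(-c4cc(F)ccc4C)cc32)cc1OC` is the next compound to be measured. It differs from compound 3 by fluoro in place of hydrogen on an aromatic carbon. Nothing measured here shows how such a change moves this read-out, so the expectation rests on compound 3 alone: since compound 3 gives 1, the step is expected to be small, estimated as a number 0.10 lower from compound 3 to compound 4 (within the scatter), downward if anything. Compound 4 is therefore expected to give 0.9, with a range of 0.7 to 1.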

Compound 4, hepatic extraction ratio in the Mus musculus assay: 1
Beside the measured number, compound 4's estimate is 0.10 below it; low and high end bracket the measured number.
By their numbers in the Mus musculus assay, from the lowest: compound 2; then compound 1; then compounds 3 and 4 (each within the scatter of the next).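

Among these compounds, in the Mus musculus assay, fluoro in place of hydrogen on an aromatic carbon, para to a methyl group, gives the first single-place step on this read-out, no change at the digits printed from compound 3 to compound 4 (within the scatter), and in a physicochemical assay for solubility (on this read-out higher numbers stand for higher solubility and lower numbers for lower solubility), the same change gives an at least 1.2-fold lower number from compound 3 to compound 4 (0.10 log units; that floor lies within the scatter). In the physicochemical assay compound 3 gives > 200000 nM, which is a limit of the assay: the limit of > 200000 nM in the physicochemical assay, at which 1 of the 2 values shown sits.
In the physicochemical assay compound 4 gives 157000 nM, so the full size of that step cannot be read.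

The compounds shown leave open whether a chloro group or a nitrile at this place would move the number in the Mus musculus assay. They also leave open whether fluoro at this place would matter on a compound whose number there lies lower, as does that of compound 2.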